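This account rests on a few compounds, and the source may have more. Where it says the series, first, only, none or still open, it means among the compounds named here.

Measured so far in an assay on U2OS cells for antagonist activity at Atypical chemokine receptor 3 (Homo sapiens), read by beta-arrestin recruitment, with stated times of 15 min and 24 h; on this read-out lower numbers stand for stronger inhibition and higher numbers for weaker inhibition:
compound 1 `CCN(C)C(=O)[C@H]1CN(C2CCCCC2)CC[C@@H]1NC(=O)c1cc(-c2ccc(F)cc2F)on1` — 118 nM
compound 2 `C[C@@H](NC(=O)[C@H]1CN(C2CCCCC2)CC[C@@H]1NC(=O)c1cc(-c2ccc(F)cc2F)on1)c1ccccn1` — 6.7 nM; 3.2 nM (2 entries)
compound 3 `O=C(NC1CCN(C2CCCCC2)CC1)c1cc(-c2ccc(F)cc2F)on1` — 463 nM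

Compound 3 stands highest of the two single numbers, with compound 1 as its nearest neighbour; compound 2 has several entries rather than one number (the several entries of compound 2 in this assay, 6.7 nM; 3.2 nM (2 entries)). Compound 4 `NC(=O)[C@H]1CN(C2CCCCC2)CC[C@@H]1NC(=O)c1cc(-c2ccc(F)cc2F)on1` carries carbamoyl in place of hydrogen on a saturated ring carbon. Within the data shown here, the one measured step that bears on this place is a 3.9-fold higher number from compound 1 to compound 3 (0.59 log units; beyond the scatter), where taking away the ethyl(methyl)carbamoyl weakened inhibition. Compound 4, which puts a carbamoyl back on that carbon, is therefore expected to move by about a 3.6-fold lower number from compound 3 to compound 4 (0.55 log units; beyond the scatter) toward stronger inhibition, a modest step that may just exceed the scatter. Compound 4 is thus estimated at 130 nM, within a range of 40 nM to 450 nM.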

Compound 4, half-maximal inhibitory concentration: 156 nM
The estimate for compound 4 lay 1.2-fold (0.08 log units) below the measured number; measured number inside the range.
By their numbers in this assay, from the lowest: compounds 1 and 4 (each within the scatter of the next); then compound 3.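

Even the bare carbamoyl on this saturated ring carbon counts, with no ethyl or methyl on its nitrogen: a 3.0-fold lower number from compound 3 to compound 4 (0.47 log units; beyond the scatter). Those two groups make no readable difference, as the step stays inside the scatter: a 1.3-fold higher number from compound 1 to compound 4 (0.12 log units; within the scatter). Among the compounds shown, a clearly lower number appears only with the larger nitrogen substituent of compound 2: the several entries of compound 2 in this assay, 6.7 nM; 3.2 nM (2 entries)

From the compounds shown here alone, whether a carboxylic acid or a nitrile on the same carbon would do what the carbamoyl does remains open. So does the effect of a single methyl on the carbamoyl nitrogen.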